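The compounds below may be only part of what the source reports. "The series", "measured", "known", "first", "only" and "open" are said of these compounds alone.

Among the measured compounds shown here, compound 1 `C[Si](C)(C)c1cn(C[C@H](O)[C@H]2OC(=O)C(OCc3ccccc3)=C2OCc2ccccc2)nn1` is the only member of the series with a numerical result: in a functional assay on SW-620 cells (Homo sapiens) for antiproliferative activity, read by MTT assay, with a stated time of 72 h (a higher number here means a weaker inhibitor, a lower number a stronger inhibitor), compound 1 gives 56000 nM. Compound 2 `CCCCCc1ccc(-c2cn(C/C=C3\OC(=O)C(OCc4ccccc4)=C3OCc3ccccc3)nn2)cc1` reaches only a limit of the assay, > 100000 nM. Compound 3 `COc1ccccc1-c1cn(C/C=C2\OC(=O)C(OCc3ccccc3)=C2OCc2ccccc2)nn1` likewise reaches only a limit, > 100000 nM. The step that the two limits leave unreadable from compound 2 to compound 3 is therefore not readable, and the limit of > 100000 nM in this assay, at which 2 of the 3 values shown sit, marks where two of the three results sit. Compound 4 `O=C1O[C@H]([C@@H](O)Cn2cc(CCCCl)nn2)C(OCc2ccccc2)=C1OCc1ccccc1` differs from compound 1 by a group of 4 heavy atoms (3 carbon, 1 chlorine; no ring) in place of a group of 4 heavy atoms (3 carbon, 1 silicon; no ring), on an aromatic carbon. For the measured compounds named here, no measured step touches this position, so no direction can be drawn from the series. The expected step of a 1.1-fold higher number from compound 1 to compound 4 (0.03 log units; within the scatter) is taken to lie within the scatter. For compound 4 the estimate in this assay is 60000 nM, between 25000 nM and 150000 nM.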

Compound 4, half-maximal inhibitory concentration: 68500 nM
Compound 4: the middle estimate sits 1.1-fold (0.06 log units) below what was measured, and the stated range covers the measured number.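

Among the compounds shown here, the only measured step at this position, on the aromatic carbon of the five-membered ring, is a 1.2-fold higher number from compound 1 to compound 4 (0.09 log units; within the scatter). In this assay, for the compounds shown here, 3-chloropropyl and the group of 3 carbon and 1 silicon are therefore not told apart at this aromatic carbon, and this position now has a measured step, which the earlier compounds did not give. No result shown offers a cause for this step.

One step sets no direction at this position. From the compounds shown here alone, whether an amine, a carboxylic acid or a longer chain here would shift the number remains open.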